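A few compounds are considered here, and "the series" means these few. Any claim that something is new, unique, unknown or untested is made for them only; others in the source may bear on it.

Measured compounds:
compound 1 `Cc1n[nH]c2ccc(-c3nc4cnc(N5CCN(C)CC5)cn4c3Nc3ccc(F)cc3)cc12` — in a functional assay on CWR22R cells (Homo sapiens) for inhibition, with a stated time of 120 h (on this read-out higher numbers stand for weaker inhibition and lower numbers for stronger inhibition), compound 1 gives 33600 nM
compound 2 `Cc1n[nH]c2ccc(-c3nc4cnc(N5CCN(C)CC5)cn4c3Nc3ccc(F)cc3Br)cc12` — in this assay compound 2 gives "not determined" (no result reported)

Among the measured compounds shown here, compound 1 is the only member of the series with a number; compound 2 carries the same core but no value, so nothing can be said of its standing. Compound 1 stands alone in this assay, and its value marks it as a weak inhibitor on this read-out.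

Compound 3 `Cc1n[nH]c2ccc(-c3nc4cnc(N5CCN(C)CC5)cn4c3Nc3ccc(F)c(Cl)c3)cc12` is not yet measured. It differs from compound 1 by chloro in place of hydrogen on an aromatic carbon, that is, a (4-fluorophenyl)amino group becoming a (3-chloro-4-fluorophenyl)amino group on the shared core.

For the measured compounds named here, no step between measured compounds exists, so the size of this change cannot be read from the data. In this assay the expected change is a 1.7-fold lower number from compound 1 to compound 3 (0.23 log units; within the scatter). Compound 3 is therefore estimated at 20000 nM, in a range from 7000 nM to 60000 nM.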

Compound 3, half-maximal inhibitory concentration: 14000 nM
For compound 3 the middle estimate is 1.4-fold (0.15 log units) above the measured one; the range from low to high includes it.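

In this assay the position ortho to the fluoro group and meta to a large group proves responsive: chloro in place of hydrogen on this aromatic carbon gives a 2.4-fold lower number from compound 1 to compound 3 (0.38 log units; beyond the scatter) and so moves the number towards stronger inhibition. Among the compounds shown here, this is the first measured step, and it shows that the 3-chloro-4-fluorophenyl group is tolerated on the shared core, with a modest gain. No measurement available here bears on the reason for this step.

On these data alone, whether a methyl group, a methoxy group or an amine at this position would give a step of similar size remains open, as does the size of the chloro step on a phenyl ring without the fluoro group. Compound 2 has no number, so any step involving it cannot be read.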